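Swapping a branched chain for a hydroxymethyl chain

The source may hold more compounds than are shown below. What is called first, only, known or untested is meant among the compounds shown, and "the series" means these compounds.

Of the compounds shown here, three sharing one core have been measured in a functional assay on HeLa cells (Homo sapiens) for cytotoxicity, read by WST assay, with a stated time of 48 h; on this read-out lower numbers stand for stronger inhibition and higher numbers for weaker inhibition. Compound 1 (`COc1cc(C(c2ccc(O)c(OC)c2)[C@@H](C)[C@@H](C)CF)ccc1O`) gives 42000 nM, compound 2 (`COC[C@H](C)[C@@H](C)C(c1ccc(O)c(OC)c1)c1ccc(O)c(OC)c1`) gives 77000 nM, and compound 3 (`COc1cc(C(c2ccc(O)c(OC)c2)[C@H](CC(C)C)C(C)C)ccc1O`) gives 8200 nM, the lowest number of the three.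

The unmeasured compound 4 (`COc1cc(C(c2ccc(O)c(OC)c2)[C@H](C)[C@@H](C)CO)ccc1O`) keeps the core but carries 2-(hydroxymethyl)-1-methylpropyl in place of the 1-isopropyl-3-methylbutyl of compound 3, on a saturated chain carbon bound to two aromatic carbons: 2-(hydroxymethyl)-1-methylpropyl in place of 1-isopropyl-3-methylbutyl on a saturated chain carbon bound to two aromatic carbons.

Two measured steps come close to this change. Each also exchanges the chain of compound 3 for a 1-methylpropyl chain with a substituted methyl group, though they run the opposite way. The data show a 5.1-fold lower number from compound 1 to compound 3 (0.71 log units; beyond the scatter) and a 9.4-fold lower number from compound 2 to compound 3 (0.97 log units; beyond the scatter), both modest but beyond the scatter. A third step, a 1.8-fold higher number from compound 1 to compound 2 (0.26 log units; within the scatter), stays within the scatter, so those two chains cannot be told apart here. No hydroxymethyl chain has been measured yet, so this remains an inference.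

Given compound 1 at 42000 nM and compound 2 at 77000 nM, a rise of similar size is expected in this assay, meaning weaker inhibition. The expected change is a 7.3-fold higher number from compound 3 to compound 4 (0.86 log units; beyond the scatter). For compound 4 the estimate is 60000 nM, with an expected range of 25000 nM to 130000 nM.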

Compound 4, half-maximal inhibitory concentration: > 100000 nM
Compound 4: only a limit was reported; the forecaster's own chance of this, stated with the estimate: 15%; middle value at least 1.6-fold (0.22 log units) away from the limit.
By their numbers in this assay, from the lowest: compound 3; then compounds 1 and 2 (each within the scatter of the next). At a limit, above all of these: compound 4.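

In this assay compound 4 gives > 100000 nM as a limit of the assay, not as a number. Even so, this position clearly responds to the chain it carries: the data give an at least 12-fold higher number from compound 3 to compound 4 (1.08 log units; beyond the scatter) when 2-(hydroxymethyl)-1-methylpropyl replaces the larger all-carbon chain, and an at least 2.3-fold higher number from compound 1 to compound 4 (0.37 log units; beyond the scatter) when it replaces 2-(fluoromethyl)-1-methylpropyl, so the hydroxymethyl chain also stands apart from the fluoromethyl chain. Against the methoxymethyl chain the result is an at least 1.2-fold higher number from compound 2 to compound 4 (0.11 log units; that floor lies within the scatter) and that floor lies within the scatter, so the effect of hydrogen in place of methyl on this oxygen cannot be read.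

As far as these compounds go, how far the true value of compound 4 lies beyond its limit stays unknown, and so does the full size of each of these steps. Also open, from the compounds shown here alone, is whether an amine or a carboxylic acid on this short chain, or a longer chain ending in a hydroxyl group, would give a number nearer to that of compound 3 or one that also reaches the limit of the assay.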